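Methylpyridinyl for pyrazinyl at the distal ring

The compounds below may be only part of what the source reports. "The series", "measured", "known", "first", "only" and "open" are said of these compounds alone.

The series shares one core and varies only the aromatic group attached to the phenyl ring. Compound 1 `CCC(C)(C)Cc1c[nH]c(CCc2ccc(-c3ccncc3)cc2)n1` gives 101 nM in an in vitro assay on CHO cells for displacement of a labelled ligand from Bombesin receptor subtype-3 (Homo sapiens), read by scintillation counting, with a stated time of 2 h; on this read-out lower numbers stand for stronger inhibition and higher numbers for weaker inhibition. Compound 2 `CCC(C)(C)Cc1c[nH]c(CCc2ccc(-c3cnccn3)cc2)n1` gives 51 nM, and compound 3 `CCC(C)(C)Cc1c[nH]c(CCc2ccc(-c3ccns3)cc2)n1` gives 11 nM. Among these three numbers compound 2 stands second highest: it lies a 2.0-fold lower number from compound 1 to compound 2 (0.30 log units; within the scatter), and a 4.6-fold lower number from compound 2 to compound 3 (0.67 log units; beyond the scatter).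

Compound 4 `CCC(C)(C)Cc1c[nH]c(CCc2ccc(-c3cccc(C)n3)cc2)n1` differs from compound 2 in one place: 6-methylpyridin-2-yl in place of pyrazin-2-yl on an aromatic carbon. Among the compounds with values here, two measured steps bear on this. The step from compound 1 to compound 2 shows that exchanging one six-membered aromatic ring with nitrogen for another leaves the number within the scatter. The step from compound 2 to compound 3 shows that only the move to 1,2-thiazol-5-yl brought a modest change beyond the scatter. Compound 4 keeps a six-membered aromatic ring with one hetero atom and adds a methyl, so no step beyond the scatter is expected; the estimated change is a 1.2-fold higher number from compound 2 to compound 4 (0.07 log units; within the scatter). Compound 4 is therefore expected to give about 60 nM, within 20 nM to 180 nM.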

Compound 4, half-maximal inhibitory concentration: 6.3 nM
Estimate against measurement, compound 4: 9.5-fold (0.98 log units) above; the measured number lies below the stated range.
By their numbers in this assay, from the lowest: compounds 4 and 3 (each within the scatter of the next); then compounds 2 and 1 (each within the scatter of the next).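

In this assay the change to 6-methylpyridin-2-yl gives an 8.1-fold lower number from compound 2 to compound 4 (0.91 log units; beyond the scatter) and, against the other six-membered ring with one hetero atom, a 16-fold lower number from compound 1 to compound 4 (1.20 log units; beyond the scatter), so a six-membered aromatic ring at this place does not by itself hold the number high. With a 1.7-fold lower number from compound 3 to compound 4 (0.24 log units; within the scatter), 1,2-thiazol-5-yl is also no longer the only group shown here that gives a low number. The data hold no measurement that explains these steps.

The change from pyrazin-2-yl alters the ring nitrogens and adds the methyl in a single step, and the compounds shown do not separate the two; plain pyridin-2-yl would be needed for that. From the compounds shown here alone, whether an ethyl, a methoxy or an amine in place of the methyl would keep the low number also remains open.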